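From compound 3 to compound 4: a relocated methyl

The source may hold more compounds than are shown below. What is called first, only, known or untested is meant among the compounds shown, and "the series" means these compounds.

In an ADME assay on microsomes from liver (Rattus norvegicus) for metabolic stability (on this read-out lower numbers stand for a shorter-lived compound and higher numbers for a longer-lived compound), compound 3 `CCn1ncc2c(F)cc(-c3ccc(C(CC)(CC)c4nnc(C)[nH]4)c(=O)[nH]3)cc21` gives > 3 h, which is a limit of the assay and not a number. Compound 1 `CCn1ncc2c(F)cc(-c3ccc(C(CC)(CC)c4nnc[nH]4)c(=O)[nH]3)cc21` gives > 3 h, also a limit. For the measured compounds named here, compound 2 `CC(C)C(Cc1nnc[nH]1)c1ccc(-c2ccc3cccc(F)c3c2)[nH]c1=O` gives 0.1 h, the only true number so far, and it differs from both of the others in more than one place.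

Compound 4 `CCn1ncc2c(F)cc(-c3ccc(C(CC)(CC)c4nncn4C)c(=O)[nH]3)cc21` departs from compound 3 by 4-methyl-4H-1,2,4-triazol-3-yl in place of 5-methyl-4H-1,2,4-triazol-3-yl on a saturated chain carbon bound to an aromatic carbon and two saturated chain carbons. The exchange is 4-methyl-4H-1,2,4-triazol-3-yl in place of 5-methyl-4H-1,2,4-triazol-3-yl on a saturated chain carbon bound to an aromatic carbon and two saturated chain carbons. The two compounds have the same atoms, joined differently.

The nearest measured step is a step that the two limits leave unreadable from compound 1 to compound 3, with methyl in place of hydrogen on an aromatic carbon. Its size cannot be read, as both ends are limits: the limit of > 3 h in this assay, at which 2 of the 3 values shown sit. Going by the values given here, no measured step covers the exchange itself, so no size can be carried over from the series. As far as these compounds go, with that step giving no measurable size, only a small change in this assay is expected, and its direction remains open. The estimated step that the limit leaves unreadable from compound 3 to compound 4 is expected to stay within the usual scatter. For compound 4 the estimate is 3.5 h, with an expected range of 1.2 h to 8 h.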

Compound 4, half-life: > 3 h
Compound 4 gave a limit, no number (the forecaster's own chance of this, stated with the estimate: 60%); the middle value is on the limit's open side.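

No step among compound 1, compound 3 and compound 4 can be read in this assay, because each of the three gives a limit and not a number: the limit of > 3 h in this assay, at which 3 of the 4 values shown sit.

The compounds shown leave open how long the half-lives of these three really are, and whether 4-methyl-4H-1,2,4-triazol-3-yl and 5-methyl-4H-1,2,4-triazol-3-yl differ at all on this read-out.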